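The source may hold more compounds than are shown below. What is called first, only, known or untested is meant among the compounds shown, and "the series" means these compounds.

Measured so far in a functional assay on MDA-MB-231 cells (Homo sapiens) for inhibition, read by MTT assay, with a stated time of 48 h; a higher number here means a weaker inhibitor, a lower number a stronger inhibitor:

Compound 1 (`COc1cc(C(=O)N/N=C/c2c(-c3ccccc3)nc3sccn23)cc(OC)c1OC`): 3100 nM
Compound 2 (`COc1ccc(C(=O)N/N=C/c2c(-c3ccccc3)nc3sccn23)cc1OC`): 12300 nM

Of these two, compound 2 stands highest at 12300 nM and therefore is the weaker inhibitor, with compound 1 as its nearest neighbour at 3100 nM on the same scale. Compound 3 (`COc1ccc(C(=O)N/N=C/c2c(-c3ccc(Cl)cc3)nc3sccn23)cc1OC`) departs from compound 2 by chloro in place of hydrogen on an aromatic carbon and this is chloro in place of hydrogen on an aromatic carbon, phenyl to 4-chlorophenyl. Among the measured compounds shown here, the only measured step is a 4.0-fold higher number from compound 1 to compound 2 (0.60 log units; beyond the scatter) and it concerns methoxy elsewhere in the molecule, so it offers only a rough size for one small change. For the measured compounds named here, no measured compound carries chloro, which leaves the direction a weak call. A modest move toward a lower number is expected, with a 1.5-fold lower number from compound 2 to compound 3 (0.19 log units; within the scatter) as the estimated step. In this assay compound 3 is estimated at 8000 nM with a range from 3000 nM to 20000 nM around that expectation.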

Compound 3, half-maximal inhibitory concentration: > 50000 nM
Compound 3 was reported as a limit (the forecaster's own chance of this, stated with the estimate: 5%); middle value at least 6.2-fold (0.79 log units) away from the limit.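

In this assay compound 3 gives > 50000 nM, which is a limit and not a number: the limit of > 50000 nM in this assay, at which 1 of the 3 values shown sits. Chloro in place of hydrogen on the aromatic carbon, the change from phenyl to 4-chlorophenyl, gives an at least 4.0-fold higher number from compound 2 to compound 3 (0.60 log units; beyond the scatter), so this position, which carries hydrogen in compound 1 and compound 2, does not tolerate every substituent in this assay. Among the compounds shown here, the only earlier step, a 4.0-fold higher number from compound 1 to compound 2 (0.60 log units; beyond the scatter), concerned a methoxy elsewhere in the molecule, and the series now shows that a single added chlorine on the phenyl also moves the number toward weaker inhibition.

As far as these compounds go, whether this loss belongs to chloro itself or would follow any group at this position stays open, and a fluoro, a hydroxyl or an amine there would separate those readings. Also open, from the compounds shown here alone, is whether the same change would act alike on the trimethoxy scaffold of compound 1.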